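An Ethoxyphenyl Amide Tested for Cell Toxicity

The compounds below may be only part of what the source reports. "The series", "measured", "known", "first", "only" and "open" are said of these compounds alone.

Compound 1 `O=C(Nc1ccccc1)c1cccc(/C=C2\CC(=O)N(c3ccccc3)C2=O)c1` gives > 100000 nM in an ADME assay on SW480 cells (Homo sapiens) for cytotoxicity, read by MTT assay, with a stated time of 72 h (a lower number here means a stronger inhibitor, a higher number a weaker inhibitor), which is a limit of the assay rather than a number. Compound 2 `COc1ccc(NC(=O)c2cccc(/C=C3\CC(=O)N(c4ccccc4)C3=O)c2)c(C)c1` gives > 100000 nM in this assay, again a limit. Compound 3 `O=C(Nc1cccc(F)c1)c1cccc(/C=C2\CC(=O)N(c3ccccc3)C2=O)c1` gives > 100000 nM in this assay, also a limit.

Compound 3 therefore stands at the limit of this assay, and so do the two other compounds, all three sitting at the limit of > 100000 nM in this assay, at which 3 of the 3 values shown sit. Because of the limit of > 100000 nM in this assay, at which 3 of the 3 values shown sit, none of the three measured steps can be read in size: a step that the two limits leave unreadable from compound 1 to compound 2, a step that the two limits leave unreadable from compound 1 to compound 3 and a step that the two limits leave unreadable from compound 2 to compound 3 all remain unreadable. The changes these steps carry on the amide-type nitrogen, including a change from phenyl to a substituted phenyl and the exchange of one substituted phenyl for another, left every compound at the limit.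

Compound 4 `CCOc1ccc(NC(=O)c2cccc(/C=C3\CC(=O)N(c4ccccc4)C3=O)c2)cc1` differs from compound 3 in one place: 4-ethoxyphenyl in place of 3-fluorophenyl on an amide-type nitrogen. This is again an exchange of one substituted phenyl for another on the amide-type nitrogen, the kind of change that so far produced no readable step. No step beyond the scatter is expected, and the result is expected most likely to be a limit once more. Compound 4 is estimated at 150000 nM, with a range from 60000 nM to 400000 nM. The expected step is a step that the limit leaves unreadable from compound 3 to compound 4.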

Compound 4, half-maximal inhibitory concentration: 91500 nM
The estimate for compound 4 lay 1.6-fold (0.21 log units) above the measured number, within the range that was stated.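

In this assay compound 4 gives 91500 nM as an actual number and not a limit, so among the four compounds only 4-ethoxyphenyl on this amide-type nitrogen brings the reading inside what the assay can report. Set against the other three compounds, this gives only floors: the data show an at least 1.0-fold lower number from compound 3 to compound 4 (0.03 log units; that floor lies within the scatter) and an at least 1.0-fold lower number from compound 2 to compound 4 (0.03 log units; that floor lies within the scatter) and also an at least 1.0-fold lower number from compound 1 to compound 4 (0.03 log units; that floor lies within the scatter) as the whole of what can be read. The true size of these steps stays unknown, so no real gain for compound 4 can be claimed: the limit of > 100000 nM in this assay, at which 3 of the 4 values shown sit.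

The compounds shown leave open whether the result belongs to ethoxy alone or extends to a longer chain such as 4-butoxyphenyl on this nitrogen. Also open, on these data alone, is what an amine or a carboxylic acid on that phenyl ring would give.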